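Swapping a Fused Bicyclic Amide for a Small Pyrazole

The compounds below may be only part of what the source reports. "The series", "measured", "known", "first", "only" and "open" are said of these compounds alone.

Measured compounds:
- Compound 1, `CN(c1ncco1)c1cnc(NCc2c(F)ccc3c2CCO3)n2cnnc12`: 1.4 uL/min
- Compound 2, `O=C1c2ccccc2CN1c1cnc(NCc2c(F)ccc3c2CCO3)n2cnnc12`: 2.7 uL/min

Two compounds sharing one core have been examined in an ADME assay on cells (Hepatocyte, Homo sapiens) for metabolic stability, read by HPLC, with a stated time of 30 min, tested at 1 uM; a lower number here means slower removal, a higher number faster removal of the compound. Compound 1 `CN(c1ncco1)c1cnc(NCc2c(F)ccc3c2CCO3)n2cnnc12` gives 1.4 uL/min in this assay, and compound 2 `O=C1c2ccccc2CN1c1cnc(NCc2c(F)ccc3c2CCO3)n2cnnc12` gives 2.7 uL/min. For the measured compounds named here, compound 2 has the higher of the two numbers, but the only measured step, a 1.9-fold higher number from compound 1 to compound 2 (0.29 log units; within the scatter), is within the scatter, so the two compounds cannot be told apart on these data.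

Compound 3 `CN(c1ccn(C)n1)c1cnc(NCc2c(F)ccc3c2CCO3)n2cnnc12` has not yet been measured. Relative to compound 2 the change is a group of 8 heavy atoms (5 carbon, 3 nitrogen; one five-membered aromatic ring with 2 hetero atoms) in place of a group of 10 heavy atoms (8 carbon, 1 nitrogen, 1 oxygen; one five-membered non-aromatic ring with 1 hetero atom, one six-membered aromatic ring of carbon only), on an aromatic carbon. Going by the values given here, the group that enters, methyl(1-methyl-1H-pyrazol-3-yl)amino, is closely related to the group that compound 1 carries at the same place, so the one measured step, a 1.9-fold higher number from compound 1 to compound 2 (0.29 log units; within the scatter), is the relevant comparison: it was within the scatter, and reversing a change of that kind is expected to move the number no further than that. The estimated step of a 1.7-fold lower number from compound 2 to compound 3 (0.23 log units; within the scatter) therefore stays within the scatter. Compound 3 is expected to give about 1.6 uL/min in this assay, with a likely range from 0.7 uL/min to 3.5 uL/min.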

Compound 3, intrinsic clearance in a liver preparation (reported as CLH), per the amount of preparation that the assay uses: < 1 uL/min
Compound 3 ended at the assay's limit; the forecaster's own chance of this, stated with the estimate: 10%; at least 1.6-fold (0.20 log units) between middle value and limit.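

In this assay compound 3 gives < 1 uL/min, which is a limit of the assay and not a number: the limit of < 1 uL/min in this assay, at which 1 of the 3 values shown sits.

Even with only a limit, the replacement on this aromatic carbon now gives a step that can be told apart from the scatter, an at least 2.7-fold lower number from compound 2 to compound 3 (0.43 log units; beyond the scatter), which the earlier step between compound 1 and compound 2 did not. The change on the nitrogen gives a less clear answer, since 1-methyl-1H-pyrazol-3-yl in place of 1,3-oxazol-2-yl gives an at least 1.4-fold lower number from compound 1 to compound 3 (0.14 log units; that floor lies within the scatter), so the two compounds cannot be separated on these data.

From the compounds shown here alone, how far the true number for compound 3 lies past the limit remains unknown, so the full size of both steps is also unknown. Also open, going by these compounds, is whether the low number would hold with an ethyl group instead of the methyl on that nitrogen, or with a simple phenyl ring in place of the 1-methyl-1H-pyrazol-3-yl group.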